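A few compounds are considered here, and "the series" means these few. Any claim that something is new, unique, unknown or untested is made for them only; others in the source may bear on it.

Measured compounds in a functional assay on RS4-11 cells (Homo sapiens) for inhibition, read by CCK-8 assay, with a stated time of 48 h, tested at 20 uM; on this read-out higher numbers stand for more inhibition of growth at the one concentration tested and lower numbers for less inhibition of growth:
compound 1 `N#C/C(=C\c1ccccc1OS(=O)(=O)c1ccc([N+](=O)[O-])cc1)C(=O)Nc1nnc(Cc2cccc3ccccc23)s1`: 58%
compound 2 `N#C/C(=C\c1ccccc1OS(=O)(=O)c1ccccc1[N+](=O)[O-])C(=O)Nc1nnc(Cc2cccc3ccccc23)s1`: 66%
compound 3 `N#C/C(=C\c1ccccc1OS(=O)(=O)c1ccc([N+](=O)[O-])cc1)C(=O)Nc1nnc(Cc2ccc(Cl)cc2)s1`: 66%

Compound 4 `N#C/C(=C\c1ccccc1OS(=O)(=O)c1ccccc1[N+](=O)[O-])C(=O)Nc1nnc(Cc2ccc(Cl)cc2)s1` remains to be measured in this assay. The cores of compound 3 and compound 4 differ from those of compound 1 and compound 2 by 4-chlorophenyl in place of naphthalen-1-yl on a saturated chain carbon bound to an aromatic carbon; in this assay this core change gave a number 8 percentage points higher from compound 1 to compound 3 (within the scatter). The change from compound 3 to compound 4 is 2-nitrophenyl in place of 4-nitrophenyl on a sulfonyl sulfur. The same change has already been measured once, from compound 1 to compound 2, as 2-nitrophenyl in place of 4-nitrophenyl on a sulfonyl sulfur, where it produced a number 8 percentage points higher from compound 1 to compound 2 (within the scatter); the place of the change is the same in both pairs, word for word. Compound 2 and compound 3 stand level at the digits reported, so the two single changes away from compound 1 land at the same reading. Compound 4 is expected to show a step of similar size, a number 4 percentage points higher from compound 3 to compound 4 (within the scatter), because the same change gave a number 8 percentage points higher from compound 1 to compound 2 (within the scatter). Compound 4 is therefore estimated at 70%, with a range from 56% to 82%.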

Compound 4, percent growth inhibition at one concentration: 65%
Compound 4: the middle estimate sits 5 percentage points above what was measured; the measured number falls inside the stated range.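

In this assay, 2-nitrophenyl in place of 4-nitrophenyl on a sulfonyl sulfur gave a number 1 percentage points lower from compound 3 to compound 4 (within the scatter), and this step does not differ meaningfully from the earlier one on the core of compound 1: the same change on two cores in this assay, a number 8 percentage points higher (within the scatter) from compound 1 to compound 2 and a number 1 percentage points lower (within the scatter) from compound 3 to compound 4, 9 percentage points apart, within the scatter of two such steps. The core change, 4-chlorophenyl in place of naphthalen-1-yl on a saturated chain carbon bound to an aromatic carbon, gave a number 1 percentage points lower from compound 2 to compound 4 (within the scatter), and it reads the same way when set beside its earlier step: the same change on two cores in this assay, a number 8 percentage points higher (within the scatter) from compound 1 to compound 3 and a number 1 percentage points lower (within the scatter) from compound 2 to compound 4, 9 percentage points apart, within the scatter of two such steps. Thus neither change is shown to depend on the core in these four compounds, but with every step inside the scatter, the series does not show that either change alters growth inhibition, or that a real effect carries from one core to the other.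

The compounds shown leave open whether an aminophenyl group on the sulfonyl sulfur, or a longer chain in place of the single saturated chain carbon, would move the reading beyond the scatter. Also open, going by these compounds, is how these four compounds would compare across a range of concentrations.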